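Eight-aryl series: butoxy in place of dimethylamino

The compounds below may be only part of what the source reports. "The series", "measured", "known", "first", "only" and "open" are said of these compounds alone.

Measured so far:
- compound 1, `CN(C)c1ccc(-c2nc3c(=O)n(C)c(=O)n(C)c3[nH]2)cc1`, in an assay for binding affinity to adenosine receptor A1 (Bos taurus) (on this read-out higher numbers stand for weaker inhibition and lower numbers for stronger inhibition), compound 1 gives 1.8 nM
- compound 2, `Cc1cccc(-c2nc3c(=O)n(C)c(=O)n(C)c3[nH]2)c1`, in this assay compound 2 gives 13 nM
- compound 3, `Cc1ccc(-c2nc3c(=O)n(C)c(=O)n(C)c3[nH]2)c(N)c1`, in this assay compound 3 gives 10 nM

Compound 1 holds the lowest number of the three; its gaps to compound 3 and to compound 2 both lie beyond the usual scatter, so on these numbers it is the most potent of the set. Compounds 2 and 3 carry a methyl on the pendant ring, compound 3 additionally an amino group, and both sit higher than compound 1.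

Compound 4, `CCCCOc1ccc(-c2nc3c(=O)n(C)c(=O)n(C)c3[nH]2)cc1`, has not been measured in this assay. It differs from compound 1 in one place: butoxy in place of dimethylamino on an aromatic carbon. For the measured compounds named here, no pair of measured compounds changes only this group, so the size of the step is not known from the data. The expectation is that compound 4 moves toward the higher numbers of compounds 2 and 3 rather than staying at the level of compound 1, a step beyond the scatter but not a large one, as the expected step of a 3.3-fold higher number from compound 1 to compound 4 (0.52 log units; beyond the scatter) shows.

For compound 4 the estimate in this assay is 6 nM, with a range from 2 nM to 20 nM.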

Compound 4, half-maximal inhibitory concentration: 4 nM
The estimate for compound 4 lay 1.5-fold (0.18 log units) above the measured number; measured number inside the range.
By their numbers in this assay, from the lowest: compound 1; then compound 4; then compounds 3 and 2 (each within the scatter of the next).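

In this assay, butoxy in place of dimethylamino on an aromatic carbon, para to a large group, gives a 2.2-fold higher number from compound 1 to compound 4 (0.35 log units; beyond the scatter), a modest step that still lies beyond the scatter. For the compounds shown here, the earlier compounds offered no single-place change, so this is the first reading of what this position allows: dimethylamino is not required to keep the number low, and a larger open-chain group with matching hydrogen-bond donor and acceptor counts shifts it only modestly. No measurement on hand bears on the cause of this step.

Left open is whether the step follows the change of linking atom or the change in chain length: methoxy, a longer chain such as hexyloxy, or dibutylamino on the same carbon would begin to separate the two. Also open, from the compounds shown here alone, is whether a group of a different kind at this position, such as a primary amine or a carboxylic acid, would stay near this level or move well away from it.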